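Anilino swap on the shared core: dimethoxy to trifluoromethyl

The source may hold more compounds than are shown below. What is called first, only, known or untested is meant among the compounds shown, and "the series" means these compounds.

Compound 1 `Cc1cc(F)ccc1Nc1ncc(C(F)(F)F)c(N2Cc3cccc(N(C)S(C)(=O)=O)c3C2)n1`: > 30000 nM
Compound 2 `COc1cc(Nc2ncc(C(F)(F)F)c(N3Cc4cccc(N(C)S(C)(=O)=O)c4C3)n2)cc(OC)c1`: 630 nM

For the measured compounds named here, in a functional assay on OVCAR-3 cells (Homo sapiens) for antiproliferative activity, read by spectrophotometry, with a stated time of 2 days (on this read-out higher numbers stand for weaker inhibition of growth and lower numbers for stronger inhibition of growth), compound 2 gives 630 nM and stands as the only number in the set. For compound 1 the value is a limit of the assay, (the limit of > 30000 nM in this assay, at which 1 of the 2 values shown sits). Going by the values given here, the single measured step, an at least 47-fold lower number from compound 1 to compound 2 (1.67 log units; beyond the scatter), shows that the anilino group weighs heavily here, although it does not tell what a single trifluoromethyl will do. Compound 3 `CN(c1cccc2c1CN(c1nc(Nc3cccc(C(F)(F)F)c3)ncc1C(F)(F)F)C2)S(C)(=O)=O` differs from compound 2 by 3-(trifluoromethyl)phenyl in place of 3,5-dimethoxyphenyl on a nitrogen on an aromatic ring. In this assay compound 3 is expected to sit weaker than compound 2, a step of a 4.8-fold higher number from compound 2 to compound 3 (0.68 log units; beyond the scatter) beyond the scatter, with an estimate of 3000 nM and a range from 800 nM to 15000 nM.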

Compound 3, concentration for 50% growth inhibition: > 30000 nM
Compound 3: no number, only a limit (the forecaster's own chance of this, stated with the estimate: 15%); at least 10-fold (1.00 log units) between middle value and limit.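

Putting 3-(trifluoromethyl)phenyl on this nitrogen gives an at least 47-fold higher number from compound 2 to compound 3 (1.67 log units; beyond the scatter) in this assay, so the activity of compound 2 does not carry over to this second replacement of its 3,5-dimethoxyphenyl. Compound 3, like compound 1, yields a limit of the assay and not a number: the limit of > 30000 nM in this assay, at which 2 of the 3 values shown sit.
The step between compound 1 and compound 3 cannot be read, and these two aryl groups cannot be ranked.

As far as these compounds go, whether activity depends on both methoxy groups stays open. So does the effect of a single methoxy group or of an amine on the phenyl ring.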